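The compounds below may be only part of what the source reports. "The series", "measured", "known", "first", "only" and "open" are said of these compounds alone.

Measured so far:
- Compound 1 `O=[N+]([O-])c1ccc(Oc2ccc(/C=N/Nc3nc4ccccc4s3)cc2)cc1`: 5.1
- Compound 2 `Cc1cc(Oc2ccc(/C=N/NC(=O)CSc3nc4ccccc4s3)cc2)ccc1Cl`: 5.7
- Compound 3 `O=C(CSc1nc2ccccc2s1)N/N=C/c1ccc(Oc2ccc3ccccc3c2)cc1`: 5.9

In a physicochemical assay for lipophilicity, in phosphate buffer, measured as octanol-water partition, with a stated time of 24 h (on this read-out lower numbers stand for lower lipophilicity and higher numbers for higher lipophilicity), compound 1 gives 5.1, the lowest of the three numbers; compound 2 sits higher by a gap beyond the scatter, and compound 3 higher still. Going by the values given here, the one step measured between two compounds that differ in a single place is a number 0.20 log units higher from compound 2 to compound 3 (within the scatter), which concerns the group on the ring oxygen, not the part of the molecule that changes here.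

Compound 4 `Cc1ccc(Oc2ccc(/C=N/Nc3nc4ccccc4s3)cc2)cc1` differs from compound 1 in one place: methyl in place of nitro on an aromatic carbon. Among the compounds with values here, no measured pair covers this exchange, so nothing in this assay directly calibrates it; the expectation rests on the structural change alone. The step expected in this assay is a number 0.60 log units higher from compound 1 to compound 4 (beyond the scatter), upward, beyond the scatter. Compound 4 is therefore estimated at 5.7, with a range from 5.2 to 6.2.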

Compound 4, partition coefficient: 5.4
Beside the measured number, compound 4's estimate is 0.30 log units above it; measured number inside the range.
By their numbers in this assay, from the lowest: compounds 1, 4, 2 and 3 (each within the scatter of the next, the first and the last beyond it).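

In this assay, going by these compounds alone, the first measured exchange at this position, methyl in place of nitro on an aromatic carbon, gives a number 0.30 log units higher from compound 1 to compound 4 (within the scatter). Nitro, with 3 heavy atoms and 2 hydrogen-bond acceptors, and methyl, with 1 heavy atom and no hydrogen-bond acceptors, therefore cannot be told apart on this read-out, at least on the core of compound 1. No supporting measurement bears on why these two groups read alike here.

The compounds shown leave open whether an amine, a carboxylic acid or a longer chain at this carbon would also stay within the scatter of compound 1. They also leave open whether the same exchange would read alike on the core of compound 2.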